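Aryl replacement on the ring nitrogen of compound 2

The source may hold more compounds than are shown below. What is called first, only, known or untested is meant among the compounds shown, and "the series" means these compounds.

Measured compounds in a functional assay on HT-29 cells (Homo sapiens) for antiproliferative activity, read by MTT assay, with a stated time of 72 h; a higher number here means a weaker inhibitor, a lower number a stronger inhibitor:
compound 1 `O=C(Nc1ccc(Oc2ccnc3[nH]ccc23)cc1)c1cc2cccnc2n(-c2ccc(Cl)cc2)c1=O` gives 280 nM
compound 2 `Cn1ccc2c(Oc3ccc(NC(=O)c4cc5cccnc5n(-c5ccc(Cl)cc5)c4=O)cc3)ccnc21` gives 730 nM

Compound 2 stands highest of the two numbers in this assay; its nearest neighbour is compound 1, and the step of a 2.6-fold higher number from compound 1 to compound 2 (0.42 log units; beyond the scatter) came with a methyl in place of hydrogen on an aromatic nitrogen.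

Compound 3 `Cn1ccc2c(Oc3ccc(NC(=O)c4cc5cccnc5n(-c5ccc(C(F)(F)F)cc5Cl)c4=O)cc3)ccnc21` differs from compound 2 in one place: 2-chloro-4-(trifluoromethyl)phenyl in place of 4-chlorophenyl on an aromatic nitrogen. The change is on an aromatic nitrogen of a six-membered aromatic ring with one nitrogen, part of a fused system of two rings.

No measured step bears on this change; the only step shown, from compound 1 to compound 2, alters a different position. The direction of the new step is therefore open. Compound 3 is expected to land near compound 2, with the step of a 1.0-fold lower number from compound 2 to compound 3 (0.02 log units; within the scatter) carrying a wide range. The estimate for compound 3 in this assay is 700 nM, between 200 nM and 2500 nM.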

Compound 3, half-maximal inhibitory concentration: 6050 nM
For compound 3 the middle estimate is 8.6-fold (0.94 log units) below the measured one; the measured number lies above the stated range.
By their numbers in this assay, from the lowest: compound 1; then compound 2; then compound 3.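

In this assay, the group on this aromatic nitrogen proves to matter: an 8.3-fold higher number from compound 2 to compound 3 (0.92 log units; beyond the scatter) is a step well beyond the scatter, made by changing only the aryl group. The earlier pair, with a 2.6-fold higher number from compound 1 to compound 2 (0.42 log units; beyond the scatter), spoke only to a methyl on a different nitrogen and said nothing about this site. The result shows that the 4-chlorophenyl cannot be exchanged for 2-chloro-4-(trifluoromethyl)phenyl without a clear cost in this assay, so the site does not accept every aryl group alike.

The change adds the second chlorine and swaps the 4-substituent together, so the compounds shown do not tell which part carries the step, or how a methoxy group or an amine on that phenyl would read. No evidence here accounts for the step.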